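A few compounds are considered here, and "the series" means these few. Any claim that something is new, unique, unknown or untested is made for them only; others in the source may bear on it.

Measured so far in a functional assay on MCF7 cells (Homo sapiens) for antiproliferative activity, read by MTT assay, with a stated time of 48 h; on this read-out higher numbers stand for weaker inhibition and lower numbers for stronger inhibition:
compound 1 `N#CC1=C(N)Oc2c(c3nc4ccccc4nc3c3ccccc23)C12C(=O)N(Cc1cnnn1-c1cccc(S(N)(=O)=O)c1)c1ccccc12` — 42500 nM
compound 2 `N#CC1=C(N)Oc2c(N)cc3nc4ccccc4nc3c2C12C(=O)N(Cc1cnnn1-c1ccc(F)cc1)c1ccccc12` — a limit of the assay, > 50000 nM

In this assay compound 1 gives 42500 nM, a weak result. For compound 2 the assay reported only a limit, > 50000 nM, so no number is known for it. Compound 2 thus stands at the limit of this assay, the point at which one of the two values shown sits (the limit of > 50000 nM in this assay, at which 1 of the 2 values shown sits). Compound 3 `Cc1ccc(Cl)cc1-n1nncc1CN1C(=O)C2(C(C#N)=C(N)Oc3c(N)cc4nc5ccccc5nc4c32)c2ccccc21` has not been measured yet. It differs from compound 2 in one place: 5-chloro-2-methylphenyl in place of 4-fluorophenyl on an aromatic nitrogen. Within the data shown here, no measured step of this kind exists among the known compounds, so the expected step in this assay is small, none beyond the usual scatter, and compound 3 is expected to remain weak, with a fair chance that only a limit is reported again. Compound 3 is estimated at 48000 nM, within 20000 nM to 120000 nM. The expected step is an at least 1.0-fold lower number from compound 2 to compound 3 (0.01 log units; that floor lies within the scatter).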

Compound 3, half-maximal inhibitory concentration: 43500 nM
For compound 3 the middle estimate is 1.1-fold (0.04 log units) above the measured one, and the stated range covers the measured number.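

In this assay, putting 5-chloro-2-methylphenyl in place of 4-fluorophenyl on the aromatic nitrogen gives an at least 1.1-fold lower number from compound 2 to compound 3 (0.06 log units; that floor lies within the scatter), so the data show no gain beyond the scatter, although the true step could be larger. Compound 3 gives this series, with its amino-bearing core, a measured number at this position, so a phenyl ring carrying both chlorine and methyl still leaves the result weak. Among these compounds, the other end of the step is a limit of the assay and not a number, the one held by compound 2: the limit of > 50000 nM in this assay, at which 1 of the 3 values shown sits.

The compounds shown leave open whether a phenyl ring bearing an amine or a carboxylic acid, or a longer carbon chain in place of the ring, would move the result beyond the scatter. They also leave open how far the true value of compound 2 lies from its limit.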